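Chloropyrimidine diamines: growth inhibition in Jurkat cells

The source may report more compounds than this note shows. Statements on the series, on what has been measured and on what is new or still open speak of the compounds shown alone.

Measured so far:
compound 1 `Cc1ccccc1Nc1nc(Nc2cccnc2)ncc1Cl` — 38600 nM
compound 2 `Cc1ccccc1Nc1nc(Nc2ccc(N3CCCCC3)cc2)ncc1Cl` — > 100000 nM
compound 3 `COc1ccc(CNc2nc(Nc3ccc(N4CCN(C)CC4)cn3)ncc2Cl)cc1` — 12900 nM

In a functional assay on Jurkat cells (Homo sapiens) for inhibition, read by CCK-8 assay, with a stated time of 48 h (on this read-out lower numbers stand for stronger inhibition of growth and higher numbers for weaker inhibition of growth), compound 1 gives 38600 nM. For compound 2 the read-out is a limit, > 100000 nM (the limit of > 100000 nM in this assay, at which 1 of the 3 values shown sits). Compound 3 gives 12900 nM, the lower of the two numbers recorded in this assay, with compound 1 next and beyond the scatter.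

Compound 4 `Cc1cc(C)c(Nc2nc(Nc3ccc(N4CCN(C)CC4)cn3)ncc2Cl)c(C)c1` differs from compound 3 by 2,4,6-trimethylphenyl in place of 4-methoxybenzyl on a nitrogen on an aromatic ring. For the measured compounds named here, no measured pair spans this change, so the direction of the step is uncertain. Compound 4 is expected near compound 3 in this assay, estimated at 15000 nM (range 4000 nM to 60000 nM), a step of a 1.2-fold higher number from compound 3 to compound 4 (0.07 log units; within the scatter) that is expected to stay within the scatter.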

Compound 4, concentration for 50% growth inhibition: 7600 nM
Compound 4: middle estimate off by 2.0-fold (0.30 log units), on the high side, and the stated range covers the measured number.
By their numbers in this assay, from the lowest: compounds 4 and 3 (each within the scatter of the next); then compound 1. At a limit, above all of these: compound 2.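

In this assay, for the compounds shown here, the exchange of 4-methoxybenzyl for 2,4,6-trimethylphenyl on this nitrogen gives a 1.7-fold lower number from compound 3 to compound 4 (0.23 log units; within the scatter) and is the first pair that differs in one place. This nitrogen carries either group with no change beyond the scatter, although the two groups have the same heavy-atom count and only the leaving one holds an oxygen and a hydrogen-bond acceptor. Still open, on these data alone, is whether a carboxylic acid, a 2-aminoethyl chain or a plain methyl on this nitrogen would keep the read-out at this level. No measured property bears on this step.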